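The compounds below may be only part of what the source reports. "The series", "measured", "known", "first", "only" and "open" are said of these compounds alone.

In a functional assay on HepG2 cells (Homo sapiens) for antiproliferative activity, read by MTT assay, with a stated time of 72 h (a higher number here means a weaker inhibitor, a lower number a stronger inhibitor), three compounds have been measured:

Compound 1, `Cn1nc(-c2nnc(-c3ccccc3)o2)c2ccccc21`: 37500 nM
Compound 2, `Cn1nc(-c2nnc(-c3cccc(Cl)c3)o2)c2ccccc21`: 21400 nM
Compound 3, `Cn1nc(-c2nnc(-c3ccccc3Br)o2)c2ccccc21`: 22300 nM

Compound 3 sits second highest of the three numbers; its nearest neighbour is compound 2, with a step of a 1.0-fold higher number from compound 2 to compound 3 (0.02 log units; within the scatter), and its furthest is compound 1, with a step of a 1.7-fold lower number from compound 1 to compound 3 (0.23 log units; within the scatter). All three values thus lie within the scatter of one another.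

Compound 4, `Cc1ccc(-c2nnc(-c3nn(C)c4ccccc34)o2)cc1`, differs from compound 3 in one place: 4-methylphenyl in place of 2-bromophenyl on an aromatic carbon. Within the data shown here, no measured pair shows this exact exchange. Among the measured compounds shown here, the steps that bear on it are those that vary the same phenyl ring: a 1.8-fold lower number from compound 1 to compound 2 (0.24 log units; within the scatter) and a 1.7-fold lower number from compound 1 to compound 3 (0.23 log units; within the scatter), both within the scatter, and a 1.0-fold higher number from compound 2 to compound 3 (0.02 log units; within the scatter), which shows that swapping one substituted phenyl for another also left the number essentially unchanged. On this basis a 4-methylphenyl is expected to give a step of a 1.1-fold higher number from compound 3 to compound 4 (0.05 log units; within the scatter) in this assay, meaning no change beyond the scatter, in either direction. Compound 4 is therefore estimated at 25000 nM, with a range from 8000 nM to 80000 nM.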

Compound 4, half-maximal inhibitory concentration: 38700 nM
For compound 4 the middle estimate is 1.5-fold (0.19 log units) below the measured one; measured number inside the range.
By their numbers in this assay, from the lowest: compounds 2, 3, 1 and 4 (each within the scatter of the next).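

In this assay, among these compounds, the step of a 1.0-fold higher number from compound 1 to compound 4 (0.01 log units; within the scatter) is the first look at a carbon-only substituent on this phenyl ring, and 4-methylphenyl stands within the scatter of the unsubstituted phenyl of compound 1. Among the compounds shown here, the steps of a 1.7-fold higher number from compound 3 to compound 4 (0.24 log units; within the scatter) and a 1.8-fold higher number from compound 2 to compound 4 (0.26 log units; within the scatter) are also within the scatter, so exchanging a halogen-bearing ring for the 4-methylphenyl ring shows no measurable difference at this position on the five-membered aromatic ring, just as the exchanges among the earlier compounds did not. All four compounds therefore lie within the scatter of one another, and no information is available to explain the values or to assign any effect to these groups.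

The compounds shown leave open whether any group on this phenyl ring can move the number beyond the scatter, for example an amine, a carboxylic acid or a methoxy group, or whether a longer chain in place of the ring can do so. They also leave open how much the place of a substituent on the ring matters, as chloro, bromo and methyl each appear only in the forms 3-chlorophenyl, 2-bromophenyl and 4-methylphenyl.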